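Ring substituent series on the shared core: methoxy step

The compounds below may be only part of what the source reports. "The series", "measured", "known", "first", "only" and "open" are said of these compounds alone.

Measured in an assay on isolated protein for inhibition of thyroid hormone receptor beta (Homo sapiens), read by fluorescence, with a stated time of 30 min; on this read-out higher numbers stand for weaker inhibition and lower numbers for stronger inhibition:
Compound 1 `CCCN(CC1CCOC1)C(=O)c1ccc2oc(NCc3cccc(Cl)c3)nc2c1` gives 214 nM
Compound 2 `CCCN(CC1CCOC1)C(=O)c1cc(Cl)c2oc(NCc3cccc(Cl)c3)nc2c1` gives 71 nM
Compound 3 `CCCN(CC1CCOC1)C(=O)c1cc(C)c2oc(NCc3cccc(Cl)c3)nc2c1` gives 35 nM

Compound 3 stands lowest of the three numbers. Its nearest neighbour is compound 2, with the step of a 2.0-fold lower number from compound 2 to compound 3 (0.31 log units; beyond the scatter), and the furthest is compound 1, with the step of a 6.1-fold lower number from compound 1 to compound 3 (0.79 log units; beyond the scatter).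

Compound 4 `CCCN(CC1CCOC1)C(=O)c1cc(OC)c2oc(NCc3cccc(Cl)c3)nc2c1` differs from compound 3 in one place: methoxy in place of methyl on an aromatic carbon. For the measured compounds named here, no measured pair in this set contains a methoxy group, so the step has no direct precedent. Going by the values given here, the steps that bear on it are those at the same place: a 3.0-fold lower number from compound 1 to compound 2 (0.48 log units; beyond the scatter) and a 6.1-fold lower number from compound 1 to compound 3 (0.79 log units; beyond the scatter) both show that replacing hydrogen with a small group at this carbon gives a modest gain, and a 2.0-fold lower number from compound 2 to compound 3 (0.31 log units; beyond the scatter) shows that the identity of that group itself shifts the number by a modest step. A methoxy group is expected to land within the span covered by compound 2 and compound 3, with a small loss against compound 3 more likely than a gain; the expected step is a 1.7-fold higher number from compound 3 to compound 4 (0.23 log units; within the scatter). The estimate for compound 4 is 60 nM, with a range from 20 nM to 180 nM.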

Compound 4, half-maximal inhibitory concentration: 12 nM
Beside the measured number, compound 4's estimate is 5.0-fold (0.70 log units) above it, outside the stated range (below it).
By their numbers in this assay, from the lowest: compound 4; then compound 3; then compound 2; then compound 1.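

Methoxy at this aromatic carbon goes beyond both methyl (a 2.9-fold lower number from compound 3 to compound 4 (0.46 log units; beyond the scatter)) and chloro (a 5.9-fold lower number from compound 2 to compound 4 (0.77 log units; beyond the scatter)), so in this assay the gain over hydrogen does not stop at methyl. For the compounds shown here, the step from the unsubstituted compound is the only large one (an 18-fold lower number from compound 1 to compound 4 (1.25 log units; beyond the scatter)), and it comes with the one change that brings an oxygen and a hydrogen-bond acceptor to this carbon. No measurement here accounts for this order of groups.

The four compounds do not separate the role of the oxygen from that of the added heavy atom, since methoxy differs from methyl in both respects. Ethyl, hydroxy and ethoxy at the same carbon would show how far the gain follows the oxygen, the chain length or both.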